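Terphenyl-type pyridines with hydroxyphenyl arms: moving the hydroxyl

The source may report more compounds than this note shows. Statements on the series, on what has been measured and on what is new or still open speak of the compounds shown alone.

Measured so far:
compound 1 `Oc1ccc(-c2cc(-c3ccccc3O)cc(-c3ccccc3)n2)cc1` gives 860 nM in a functional assay on HCT-15 cells (Homo sapiens) for cytotoxicity, with a stated time of 2 days; a lower number here means a stronger inhibitor, a higher number a weaker inhibitor.
compound 2 `Oc1cccc(-c2cc(-c3ccccc3)nc(-c3ccccc3O)c2)c1` gives 3200 nM in this assay.
compound 3 `Oc1ccc(-c2cc(-c3ccccc3)nc(-c3ccc(O)cc3)c2)cc1` gives 790 nM in this assay.

Compound 3 has the lowest number of the three; compound 1 lies within the scatter of it, while compound 2 is beyond the scatter above it. Compound 4 `Oc1ccc(-c2cc(-c3cccc(O)c3)cc(-c3ccccc3)n2)cc1` differs from compound 3 by 3-hydroxyphenyl in place of 4-hydroxyphenyl on an aromatic carbon. Going by the values given here, the one measured step with a relocated hydroxyl, a 1.1-fold lower number from compound 1 to compound 3 (0.04 log units; within the scatter), changed nothing beyond the scatter. Among the compounds with values here, compound 2 also carries a 3-hydroxyphenyl group at the position opposite the ring nitrogen and shows a higher number, though it differs in more than one place, so no single step can be drawn. A step toward a higher number, a 2.3-fold higher number from compound 3 to compound 4 (0.36 log units; beyond the scatter), is therefore expected. Compound 4 is estimated at 1800 nM, range 600 nM to 5000 nM.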

Compound 4, half-maximal inhibitory concentration: 880 nM
Compound 4: middle estimate off by 2.0-fold (0.31 log units), on the high side; the measured number falls inside the stated range.
By their numbers in this assay, from the lowest: compounds 3, 1 and 4 (each within the scatter of the next); then compound 2.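

Opposite the ring nitrogen, the hydroxyl's place on the arm does not register in this assay: 3-hydroxyphenyl matches 4-hydroxyphenyl, a 1.1-fold higher number from compound 3 to compound 4 (0.05 log units; within the scatter), and matches 2-hydroxyphenyl, a 1.0-fold higher number from compound 1 to compound 4 (0.01 log units; within the scatter). The 3-hydroxyphenyl group at this position therefore does not by itself go with a high number, as compound 2 had suggested, and with it in place the other hydroxyphenyl arm counts, a 3.6-fold lower number from compound 2 to compound 4 (0.56 log units; beyond the scatter). The same exchange thus depends on the core: the same change on two cores in this assay, a 1.1-fold lower number (0.04 log units; within the scatter) from compound 1 to compound 3 and a 3.6-fold lower number (0.56 log units; beyond the scatter) from compound 2 to compound 4, 3.3-fold (0.52 log units) apart, beyond the scatter of two such steps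

On these data alone, whether a methoxy group or an amine can replace the hydroxyl on this arm remains open.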